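This account rests on a few compounds, and the source may have more. Where it says the series, first, only, none or still open, it means among the compounds named here.

Compound 1, `ClCc1ccc(Cn2cnc3c(Cl)ncnc32)cc1`, compound 2, `ClCc1cccc(Cn2cnc3ncnc(Cl)c32)c1`, and compound 3, `ClCc1ccc(Cn2cnc3c(Cl)nc(Cl)nc32)cc1`, were each tested in a functional assay on COLO 205 cells (Homo sapiens) for cytotoxicity, read by sulforhodamine B assay, with a stated time of 48 h; on this read-out lower numbers stand for stronger inhibition of growth and higher numbers for weaker inhibition of growth. In this assay compound 1 gives 2230 nM, compound 2 gives 2630 nM, and compound 3 gives 3470 nM. The three numbers sit close together; the step of a 1.6-fold higher number from compound 1 to compound 3 (0.19 log units; within the scatter) corresponds to the change (chloro in place of hydrogen on an aromatic carbon), and compound 2 stands between the other two, within the scatter of both. Compound 1 and compound 2 are built from the same atoms joined differently, and the difference between the two cores is not broken down here.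

Compound 4, `ClCc1cccc(Cn2cnc3nc(Cl)nc(Cl)c32)c1`, has not yet been measured in this assay. It differs from compound 2 by chloro in place of hydrogen on an aromatic carbon, the same change that separates compound 3 from compound 1. Among the compounds with values here, the only guide to its effect is the single measured example, in which the step from compound 1 to compound 3 stayed within the scatter. Within the data shown here, on that basis the expected step from compound 2 to compound 4 is a 1.6-fold higher number from compound 2 to compound 4 (0.20 log units; within the scatter), a small rise in the number of the same size as before, because the step of a 1.6-fold higher number from compound 1 to compound 3 (0.19 log units; within the scatter) is the one precedent available. Compound 4 is therefore estimated to give about 4200 nM in this assay, with a plausible range from 2500 nM to 7500 nM, since a change seen only once gives a weak foundation for a narrower expectation.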

Compound 4, concentration for 50% growth inhibition: 410 nM
The estimate for compound 4 lay 10-fold (1.01 log units) above the measured number, outside the stated range (below it).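

In this assay, the chloro that enters between two ring nitrogen atoms gives a 6.4-fold lower number from compound 2 to compound 4 (0.81 log units; beyond the scatter), a drop beyond the scatter, whereas the same change on the other core gave a 1.6-fold higher number from compound 1 to compound 3 (0.19 log units; within the scatter), which stayed within it. The change therefore did not carry over from one core to the other in this series, and the two steps are clearly different: the same change on two cores in this assay, a 1.6-fold higher number (0.19 log units; within the scatter) from compound 1 to compound 3 and a 6.4-fold lower number (0.81 log units; beyond the scatter) from compound 2 to compound 4, 10-fold (1.00 log units) apart, beyond the scatter of two such steps. Within the data shown here, this shows that, for these two pairs, the size of the step depends on the core that carries the change, but with only one pair on each core it does not show which feature of the cores is responsible, why the steps part, or what the change would do on any further core.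

The compounds shown leave open how an amine or a methoxy group would behave in place of that chloro on either core, and so whether the drop on the core of compound 2 belongs to chloro in particular. Also open, from the compounds shown here alone, is what a plain methyl group in place of the chloromethyl group would do to the numbers in this assay and to the gap between the two steps.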